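The source may hold more compounds than are shown below. What is called first, only, known or untested is meant among the compounds shown, and "the series" means these compounds.

Measured in a functional assay on HT-29 cells (Homo sapiens) for inhibition, with a stated time of 72 h; a higher number here means a weaker inhibitor, a lower number a stronger inhibitor:
- compound 1 `COc1ccc(S(=O)(=O)N2CCc3cccc(-c4ccc(N)cc4)c32)cc1`: 301 nM
- compound 2 `COc1ccc(S(=O)(=O)N2CCc3cccc(-c4ccc(F)c(F)c4)c32)cc1`: 57 nM
- compound 3 `COc1ccc(S(=O)(=O)N2CCc3cccc(-c4ccc(N(C)C)cc4)c32)cc1`: 467 nM

Compound 3 cannot be told apart from compound 1, as a 1.6-fold higher number from compound 1 to compound 3 (0.19 log units; within the scatter) shows, but it stands clearly on the weaker side of compound 2, with an 8.2-fold higher number from compound 2 to compound 3 (0.91 log units; beyond the scatter). Compound 4 `COc1ccc(-c2cccc3c2N(S(=O)(=O)c2ccc(OC)cc2)CC3)cc1` keeps the shared core and alters one group: methoxy in place of dimethylamino on an aromatic carbon. In words, methoxy replaces dimethylamino on an aromatic carbon, para to a large group.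

For the measured compounds named here, no measured step makes this exact exchange, so the evidence is indirect. Changing the group at this place on the ring moved the number little in one case, and the two larger steps involve compound 2, which carries two fluorines and no nitrogen group. Those steps are a 5.3-fold lower number from compound 1 to compound 2 (0.72 log units; beyond the scatter) and the step to compound 3 already given. Compound 4 also lacks a nitrogen group on that ring, so a move towards compound 2, at 57 nM, seems more likely than none, though three compounds cannot settle this. The expected change is a 3.1-fold lower number from compound 3 to compound 4 (0.49 log units; beyond the scatter), a modest step to a lower number. For compound 4 the estimated value is 150 nM, with an expected range of 50 nM to 450 nM.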

Compound 4, half-maximal inhibitory concentration: 277 nM
The estimate for compound 4 lay 1.8-fold (0.27 log units) below the measured number; the measured number falls inside the stated range.
By their numbers in this assay, from the lowest: compound 2; then compounds 4, 1 and 3 (each within the scatter of the next).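

In this assay, methoxy in place of dimethylamino on this aromatic carbon, para to a large group, gives a step within the scatter (a 1.7-fold lower number from compound 3 to compound 4 (0.23 log units; within the scatter)), and methoxy in place of amino does the same (a 1.1-fold lower number from compound 1 to compound 4 (0.04 log units; within the scatter)), so the amino, dimethylamino and methoxy compounds cannot be told apart. Having no nitrogen group on this ring is therefore not enough to reach the low number of compound 2, since the 4-methoxyphenyl compound remains clearly on the weaker side of the 3,4-difluorophenyl compound (a 4.9-fold higher number from compound 2 to compound 4 (0.69 log units; beyond the scatter)), and compound 2 alone stands apart among the four. No measurement offered here accounts for these numbers or for this separation.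

The compounds shown leave open whether the separation of compound 2 depends on fluorine itself or on having two groups on the ring, a question that a phenyl ring with a single fluorine, a single chlorine or a plain phenyl ring could help to answer. They also leave open how a larger group at this place, such as a morpholine or a carboxylic acid, would read in this assay.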